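A few compounds are considered here, and "the series" means these few. Any claim that something is new, unique, unknown or untested is made for them only; others in the source may bear on it.

Three compounds of the series have been run in a functional assay on the whole organism (strain Swiss albino) for inhibition, with Mus musculus as the target, read by paw edema, with stated times of 30 min and 270 min, at a dose of 100 mg/kg by the subcutaneous route; on this read-out lower numbers stand for less inhibition and higher numbers for more inhibition at the one dose given (going by the name of the read-out). Compound 1 `CCOC(=O)C1CCN(C(=O)c2cc(-c3ccc(C)cc3)nn2Cc2ccccc2)CC1` gives 54.4%. Compound 2 `Cc1ccc(-c2cc(C(=O)NCc3cccnc3)n(Cc3ccccc3)n2)cc1` gives 24.4%, and compound 3 `Cc1ccc(-c2cc(C(=O)Oc3ccc(C(C)C)cc3)n(Cc3ccccc3)n2)cc1` gives 29%. Compound 3 stands second highest of the three numbers; its gap to compound 2 lies within the scatter, its gap to compound 1 beyond it. Among the measured compounds shown here, the only measured step, a number 4.6 percentage points higher from compound 2 to compound 3 (within the scatter), alters the group on the carbonyl carbon and bears little on the aromatic carbon varied here. Compound 4 `Cc1ccc(-c2cc(C(=O)Oc3ccc(Oc4ccc(C(F)(F)F)cc4)cc3)n(Cc3ccccc3)n2)cc1` differs from compound 3 by 4-(trifluoromethyl)phenoxy in place of isopropyl on an aromatic carbon. For the measured compounds named here, no measured step touches that aromatic carbon, so no change beyond the scatter is expected; the estimated step is no change at the digits printed from compound 3 to compound 4 (within the scatter). Compound 4 is expected to give 29%, within 15% to 43%.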

Compound 4, a percentage reported as inhibition, in the whole organism at one dose (the size of the read-out at that dose, not a potency): 22.2%
The estimate for compound 4 lay 6.8 percentage points above the measured number; measured number inside the range.
By their numbers in this assay, from the lowest: compounds 4, 2 and 3 (each within the scatter of the next); then compound 1.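

In this assay, among the compounds shown here, the only change read so far on this aromatic carbon gives a number 6.8 percentage points lower from compound 3 to compound 4 (within the scatter). The larger 4-(trifluoromethyl)phenoxy, with its added aromatic ring, therefore takes the place of isopropyl without a shift beyond the scatter. No measurement at hand accounts for this result.

On these data alone, whether an amine or a carboxylic acid on this carbon would move the number beyond the scatter remains open. A single step also leaves open whether the same replacement would behave alike with a different group on the carbonyl carbon.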